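A few compounds are considered here, and "the series" means these few. Any claim that something is new, unique, unknown or untested is made for them only; others in the source may bear on it.

Compound 1 `COc1cccc(CN2CCC=C(CCC(=O)NO)C2=O)c1`: > 10000 nM
Compound 2 `CC(=O)Nc1ccc(CN2CCC=C(CCC(=O)NO)C2=O)cc1`: > 10000 nM

Both compounds were tested in a functional assay on PC-3 cells (Homo sapiens) for inhibition, read by sulforhodamine B assay; a lower number here means a stronger inhibitor of growth, a higher number a weaker inhibitor of growth. Compound 1 reads > 10000 nM, which is a limit of the assay and not a number. On these data alone, compound 2 reads > 10000 nM, which is also a limit, so its exact place on the scale is unknown. The whole record so far is the limit of > 10000 nM in this assay, at which 2 of the 2 values shown sit.

Compound 3 `COc1ccc(CN2CCC=C(CCC(=O)NO)C2=O)cc1` differs from compound 2 in one place: methoxy in place of acetamido on an aromatic carbon. Methoxy stands in place of acetamido on an aromatic carbon, para to a large group. Within the data shown here, no measured step shows what such a swap does. The expectation therefore rests on compound 2, with its reading of > 10000 nM, and no change beyond the scatter is expected in this assay. The expected step is a number no higher from compound 2 to compound 3 (the limit leaves the size open). The estimated value of compound 3 is 10000 nM, within an expected range from 3000 nM to 30000 nM.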

Compound 3, concentration for 50% growth inhibition: 7080 nM
Estimate against measurement, compound 3: 1.4-fold (0.15 log units) above; low and high end bracket the measured number.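

In this assay, compound 3 is the only one of the three compounds shown that gives a measured number rather than a limit, so a methoxy group at this place, para to a large group, allows a reading on the scale. Replacing acetamido with methoxy gives an at least 1.4-fold lower number from compound 2 to compound 3 (0.14 log units; that floor lies within the scatter); this is only a floor, so the true size of the change could be small or much larger. Even so, this single reading gives later changes at this place a number to be compared with, although most of the record still rests on a limit: the limit of > 10000 nM in this assay, at which 2 of the 3 values shown sit.

On these data alone, the true distance between these two compounds remains unknown. As far as these compounds go, it is also open whether an amine, a carboxylic acid or a longer chain such as ethoxy at this place would lower the number further.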